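Solubility notes on compounds 1 to 4

The compounds below may be only part of what the source reports. "The series", "measured", "known", "first", "only" and "open" are said of these compounds alone.

Measured so far:
compound 1 `C=CC(=O)N1CCC[C@H](N2C(=O)N(Cc3ccccc3)Cc3cnc(Nc4ccc(N5CCN(C)CC5)cc4OC)nc32)C1` gives 129 ug/mL
compound 2 `C=CC(=O)N1CC[C@H](N2C(=O)N(c3ccccc3)Cc3cnc(Nc4ccc(N5CCN(C)CC5)cc4)nc32)C1` gives 976 ug/mL
compound 3 `C=CC(=O)N1CC[C@H](N2C(=O)N(c3ccccc3)Cc3cnc(Nc4ccc(N5CCN(C)CC5)c(Cl)c4)nc32)C1` gives 215 ug/mL

Compound 3 stands second highest of the three numbers in a physicochemical assay for solubility, read by HPLC, in phosphate buffer, measured as thermodynamic solubility, with a stated time of 24 h, at pH 6.8; a lower number here means a less soluble compound, a higher number a more soluble compound. Its gap to compound 1 is within the usual scatter, so the two cannot be ordered; its gap to compound 2 is beyond the scatter, compound 2 giving the clearly higher number. Among the measured compounds shown here, the one step that bears on the present change is a 4.5-fold lower number from compound 2 to compound 3 (0.66 log units; beyond the scatter), a modest but real drop.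

Compound 4 is `C=CC(=O)N1CC[C@H](N2C(=O)N(c3ccccc3)Cc3cnc(Nc4ccc(N5CCN(C)CC5)c(C(F)(F)F)c4)nc32)C1`. Its difference from compound 3 is trifluoromethyl in place of chloro on an aromatic carbon. For the measured compounds named here, no measured pair covers chloro against trifluoromethyl directly, so the only guide is the size of the step into compound 3 and the fact that the new group is again without donors or acceptors. A further small decrease is expected, likely within or just beyond the scatter.

Compound 4 is estimated at 100 ug/mL, with a range of 30 ug/mL to 300 ug/mL, corresponding to an expected 2.2-fold lower number from compound 3 to compound 4 (0.33 log units; beyond the scatter).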

Compound 4, solubility: 60.9 ug/mL
Beside the measured number, compound 4's estimate is 1.6-fold (0.22 log units) above it, within the range that was stated.
By their numbers in this assay, from the lowest: compound 4; then compounds 1 and 3 (each within the scatter of the next); then compound 2.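

At the aromatic carbon ortho to a 4-methylpiperazin-1-yl group, three substituents can now be compared in this assay, and the numbers separate all three: hydrogen, then chloro, then trifluoromethyl, from highest to lowest. Chloro and trifluoromethyl are not interchangeable here, although neither has hydrogen-bond donors or acceptors: the exchange gives a 3.5-fold lower number from compound 3 to compound 4 (0.55 log units; beyond the scatter) and so adds a second step beyond the scatter. Counted from hydrogen, the trifluoromethyl change gives a 16-fold lower number from compound 2 to compound 4 (1.20 log units; beyond the scatter), a large step, whereas the chloro change was modest.

Still open, on these data alone, is whether an amine, a carboxylic acid or a nitrile at this position would stay closer to compound 2 than these two groups do, and whether the same order holds on the core of compound 1. No evidence in hand bears on why the numbers fall in this order.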